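The compounds below may be only part of what the source reports. "The series", "measured", "known", "first", "only" and "open" are said of these compounds alone.

Compound 1 `Cc1ccc(C)n1-c1ccc(C(=O)N/N=C/c2ccc(Br)cc2)cc1` — "not determined" (no result reported) in the cytotoxicity assay.
Compound 2 `O=[N+]([O-])c1ccccc1-c1nnc(-c2ccc(-n3cccc3)cc2)o1` — 266000 nM in an ADME assay on Vero cells (Chlorocebus sabaeus) for cytotoxicity, read by MTT assay, with a stated time of 72 h; a higher number here means a weaker inhibitor, a lower number a stronger inhibitor.
Compound 3 `C/C(=N/NC(=O)c1ccc(-n2c(C)ccc2C)cc1)c1ccc(N)cc1` — "not determined" (no result reported) in this assay.

Of the three measured compounds, only compound 2 carries a number: in this assay compound 2 gives 266000 nM, while compound 1 and compound 3 have no reported result. Within the data shown here, compound 2 therefore stands alone; there is no second value against which to place it, and no step between measured compounds can be drawn.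

Compound 4 `c1ccc(-c2nnc(-c3ccc(-n4cccc4)cc3)o2)cc1` is the next compound to be measured in this assay. It differs from compound 2 in one place: hydrogen in place of nitro on an aromatic carbon. Among the measured compounds shown here, no measured pair shows what this change does in this assay, so the expectation rests only on the value of compound 2 and on the small size of the change. The expected step from compound 2 to compound 4 is a 1.1-fold lower number from compound 2 to compound 4 (0.03 log units; within the scatter), which is taken to lie within the scatter, with no direction favoured.

Compound 4 is accordingly expected to give about 250000 nM in this assay, with a range from 100000 nM to 600000 nM.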

Compound 4, half-maximal inhibitory concentration: 250000 nM
Compound 4: middle estimate and measured number agree at the digits printed; the measured number falls inside the stated range.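

Among these compounds, this gives the first readable step in this assay, and it concerns an aromatic carbon ortho to a large group, where hydrogen in place of nitro gives a 1.1-fold lower number from compound 2 to compound 4 (0.03 log units; within the scatter). Compound 2 and compound 4 therefore cannot be told apart here, so the nitro group, with its three heavy atoms and two hydrogen-bond acceptors, can be removed from this place without a change beyond the scatter in this read-out. No measurement shown here explains this result.

The compounds shown leave open whether an amine or a carboxylic acid on the same aromatic carbon would also stay within the scatter of compound 4. They also leave open whether a nitro group elsewhere on this ring would behave as it does here.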